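This account rests on a few compounds, and the source may have more. Where it says the series, first, only, none or still open, it means among the compounds named here.

Working notes on the sulfone series, read in a functional assay on K562 cells (Homo sapiens) for inhibition, read by trypan blue exclusion, with a stated time of 72 h; on this read-out higher numbers stand for weaker inhibition and lower numbers for stronger inhibition. Compound 1 (`Cn1c(=O)c(S(=O)(=O)Cc2ccc(F)cc2F)cc2cnc(Nc3ccc4[nH]ccc4c3)nc21`) gives 1000 nM and compound 2 (`Cn1c(=O)c(S(=O)(=O)Cc2ccc(F)cc2)cc2cnc(Nc3ccc4[nH]ccc4c3)nc21`) gives 30000 nM. Replacing one fluoro with hydrogen on an aromatic carbon is a large change, a 30-fold higher number from compound 1 to compound 2 (1.48 log units; beyond the scatter). Compound 3 (`Cc1ccc(S(=O)(=O)c2cc3cnc(Nc4cnc5c(c4)CC(=O)N5)nc3n(C)c2=O)cc1`), at 15000 nM, lies within the scatter of compound 2 and has a higher number than compound 1.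

Compound 4 (`Cc1ccc(S(=O)(=O)c2cc3cnc(Nc4ccc5[nH]ccc5c4)nc3n(C)c2=O)cc1`) differs from compound 3 in one place: a group of 9 heavy atoms (8 carbon, 1 nitrogen; one five-membered aromatic ring with 1 hetero atom, one six-membered aromatic ring of carbon only) in place of a group of 10 heavy atoms (7 carbon, 2 nitrogen, 1 oxygen; one five-membered non-aromatic ring with 1 hetero atom, one six-membered aromatic ring with 1 hetero atom), on a nitrogen on an aromatic ring. Going by the values given here, the group on the sulfonyl stays as in compound 3 and is not the one carried by compound 1 or compound 2. Among the compounds with values here, no measured step isolates the exchange to 1H-indol-5-yl. Within the data shown here, the only step available, a 30-fold higher number from compound 1 to compound 2 (1.48 log units; beyond the scatter), is a change elsewhere in the molecule, so it bears on this one only indirectly. It shows that a small edit can move this series strongly, which argues for a wide range. Compound 1 and compound 2 both carry 1H-indol-5-yl, and their two values lie on either side of the value of compound 3, so that group alone does not fix a number.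

A moderate move toward stronger inhibition is expected, with the direction uncertain: a 3.0-fold lower number from compound 3 to compound 4 (0.48 log units; beyond the scatter). The estimate for compound 4 is 5000 nM, with an expected range from 800 nM to 30000 nM.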

Compound 4, half-maximal inhibitory concentration: 750 nM
Compound 4: middle estimate off by 6.7-fold (0.82 log units), on the high side; the whole stated range lies above it.
By their numbers in this assay, from the lowest: compounds 4 and 1 (each within the scatter of the next); then compounds 3 and 2 (each within the scatter of the next).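

In this assay, with 4-methylphenyl held on the sulfonyl sulfur, 1H-indol-5-yl entering on the nitrogen on an aromatic ring in place of the group of 10 heavy atoms gives a large step, a 20-fold lower number from compound 3 to compound 4 (1.30 log units; beyond the scatter), so this exchange alone moves the series strongly. With 1H-indol-5-yl held, the outcome at the sulfonyl sulfur depends on the group replaced: 4-methylphenyl in place of 4-fluorobenzyl gives a large step, a 40-fold lower number from compound 2 to compound 4 (1.60 log units; beyond the scatter), whereas 4-methylphenyl in place of 2,4-difluorobenzyl gives a 1.3-fold lower number from compound 1 to compound 4 (0.12 log units; within the scatter), leaving those two groups within the scatter of each other. Nothing available accounts for either large step.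

Going by these compounds alone, whether the exchange on the nitrogen keeps its size with 2,4-difluorobenzyl or 4-fluorobenzyl on the sulfonyl sulfur remains open, since the only pair that isolates it carries 4-methylphenyl. Also open, on these data alone, is what an amine or a carboxylic acid in place of 4-methylphenyl on the sulfonyl sulfur would give in this assay.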